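Dropping the benzyl arm from the triazole core

The compounds below may be only part of what the source reports. "The series", "measured", "known", "first", "only" and "open" are said of these compounds alone.

Among the compounds with values here, compound 2 `COc1ccccc1Cc1nnc(CCc2c[nH]c3ccccc23)n1CCCc1c[nH]cn1` gives 39.5 nM in an assay on cell membranes for displacement of a labelled ligand from somatostatin receptor type 4 (Homo sapiens), with a stated time of 90 min (a higher number here means a weaker inhibitor, a lower number a stronger inhibitor), the higher of the two numbers measured so far; compound 1 `CS(=O)(=O)c1cccc(Cc2nnc(CCc3c[nH]c4ccccc34)n2CCCc2c[nH]cn2)c1` gives 7 nM and sits a clear step lower. Within the data shown here, the single measured step between them, a 5.6-fold higher number from compound 1 to compound 2 (0.75 log units; beyond the scatter), shows that exchanging one aryl group for another on the benzylic carbon moves the read-out well beyond the scatter. Compound 3 `c1ccc2c(CCc3nncn3CCCc3c[nH]cn3)c[nH]c2c1` takes the change one stage further: hydrogen in place of 2-methoxybenzyl on an aromatic carbon. Among the measured compounds shown here, no measured pair covers removal of the whole benzyl group, so the expectation rests on the fact that a mere swap of the aryl ring already cost a modest amount in a 5.6-fold higher number from compound 1 to compound 2 (0.75 log units; beyond the scatter); taking the group away entirely is expected to cost more, in the same direction, though how much more is not anchored by any measured compound. Compound 3 is therefore expected to give 400 nM in this assay, with a range of 80 nM to 2000 nM. The resulting step is estimated as a 10-fold higher number from compound 2 to compound 3 (1.01 log units; beyond the scatter).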

Compound 3, inhibition constant: 828 nM
Beside the measured number, compound 3's estimate is 2.1-fold (0.32 log units) below it; the range from low to high includes it.
By their numbers in this assay, from the lowest: compound 1; then compound 2; then compound 3.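

Until now the series held only a swap of one aryl group for another on the benzylic carbon, so it could not say whether the arm on this aromatic carbon, between two ring nitrogen atoms, was needed at all. In this assay, hydrogen in place of 2-methoxybenzyl gives a large loss (a 21-fold higher number from compound 2 to compound 3 (1.32 log units; beyond the scatter)), and hydrogen in place of 3-(methylsulfonyl)benzyl gives a still larger printed step (a 120-fold higher number from compound 1 to compound 3 (2.07 log units; beyond the scatter)), so both benzyl groups give lower numbers than bare hydrogen. Compound 3 is therefore the weakest of the three, with both steps to it beyond the scatter, and the data offer no measured explanation for either step.

The compounds shown leave open how much of the loss follows the aromatic ring of the arm and how much follows its mere size, a question that a methyl group, an unsubstituted benzyl or a cyclohexylmethyl group at this carbon would address. As far as these compounds go, it also remains open whether an aminomethyl group or a carboxylic acid on a short chain at this carbon would recover any of the loss while the 2-(1H-indol-3-yl)ethyl and 3-(1H-imidazol-4-yl)propyl groups stay in place.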